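The source may hold more compounds than are shown below. What is called first, only, known or untested is meant among the compounds shown, and "the series" means these compounds.

In a functional assay on NCI-H460 cells (Homo sapiens) for cytotoxicity, read by sulforhodamine B assay, with a stated time of 48 h (on this read-out higher numbers stand for weaker inhibition of growth and lower numbers for stronger inhibition of growth), three compounds have been measured:

compound 1 `Nc1nc(Cl)c2ncn(Cc3ccc(CCl)cc3)c2n1` gives 4270 nM
compound 2 `ClCc1cccc(Cn2cnc3c(Cl)nc(Cl)nc32)c1` gives 2340 nM
compound 3 `ClCc1ccc(Cn2cnc3c(Cl)nc(Cl)nc32)cc1` gives 2400 nM

Compound 1 and compound 3 differ in one place, (amino in place of chloro on an aromatic carbon), and in this assay this gives a 1.8-fold higher number from compound 3 to compound 1 (0.25 log units; within the scatter). Compound 2 and compound 3 are built from the same atoms joined differently; the difference between the two cores is not broken down here, and their values lie close together.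

Compound 4 `Nc1nc(Cl)c2ncn(Cc3cccc(CCl)c3)c2n1` has not yet been measured. It stands to compound 2 as compound 1 stands to compound 3: the change is amino in place of chloro on an aromatic carbon, and the surroundings of the place are described in the same words for both pairs, so it is the same change on a different core. Since the earlier step, from compound 3 to compound 1, stayed within the scatter, the step from compound 2 to compound 4 in this assay is expected to be of similar size, a 1.7-fold higher number from compound 2 to compound 4 (0.23 log units; within the scatter). Compound 4 is therefore estimated at 4000 nM, with a likely range from 2000 nM to 8000 nM.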

Compound 4, concentration for 50% growth inhibition: 4260 nM
The estimate for compound 4 lay 1.1-fold (0.03 log units) below the measured number; measured number inside the range.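

In this assay, amino in place of chloro on an aromatic carbon gives a 1.8-fold higher number from compound 2 to compound 4 (0.26 log units; within the scatter). Set beside the earlier step, the change carries over from one core to the other with no visible difference: the same change on two cores in this assay, a 1.8-fold higher number (0.25 log units; within the scatter) from compound 3 to compound 1 and a 1.8-fold higher number (0.26 log units; within the scatter) from compound 2 to compound 4, 1.0-fold (0.01 log units) apart, within the scatter of two such steps. Among the compounds shown here, both steps lie within the scatter, however, so these pairs show only that the swap leaves no clear mark on growth inhibition on either core; they do not show a real effect of shared size, and two cores cannot speak for the rest of the series.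

The compounds shown leave open whether a different group on the same carbon, such as methoxy, a methylamino group or a longer amine, would move the number beyond the scatter. As far as these compounds go, all four compounds also carry a chloromethyl group, so it remains open how the numbers would respond if that group gave way to another, such as a hydroxymethyl group or a plain methyl.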